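The source may report more compounds than this note shows. Statements on the series, on what has been measured and on what is new or still open speak of the compounds shown alone.

Compound 1 `CCCCOc1ccc(-c2nc3ncccn3c2NC(C)(C)CC(C)(C)C)cc1` gives 29000 nM in a toxicity assay on A549 cells (Homo sapiens) for cytotoxicity, read by luminescence and CellTiter-Glo, with a stated time of 48 h; on this read-out lower numbers stand for higher toxicity in this test and higher numbers for lower toxicity in this test. Compound 2 `CC(C)(C)CC(C)(C)Nc1c(-c2ccc(Br)cc2)nc2ncccn12` differs from compound 1 by bromo in place of butoxy on an aromatic carbon, and the measured step is a 1.1-fold higher number from compound 1 to compound 2 (0.04 log units; within the scatter). Compound 3 `CCCCOc1ccc(-c2nc3ncccn3c2NC2CCCCC2)c(C)c1` gives 32000 nM in this assay; compound 2 gives 32000 nM there, so the two stand level at the digits shown, and both lie close to compound 1 as well. The difference between the core of compound 3 and the core of compound 1 is not broken down here.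

Compound 4 `Cc1cc(Br)ccc1-c1nc2ncccn2c1NC1CCCCC1` has not yet been measured. It differs from compound 3 by bromo in place of butoxy on an aromatic carbon. Among the measured compounds shown here, this is the same kind of change as the one that led from compound 1 to compound 2, but the surroundings are not identical: in compound 4 the aromatic carbon that carries the new group is also meta to a methyl group, whereas in compound 2 it is only para to a large group. The earlier step of a 1.1-fold higher number from compound 1 to compound 2 (0.04 log units; within the scatter) stayed within the scatter. On that basis, a step of about a 1.0-fold higher number from compound 3 to compound 4 (0.01 log units; within the scatter) in this assay is expected. Compound 4 is therefore estimated at 33000 nM, with a likely range from 16000 nM to 70000 nM.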

Compound 4, half-maximal cytotoxic concentration: 45000 nM
Compound 4: the middle estimate sits 1.4-fold (0.13 log units) below what was measured, and the stated range covers the measured number.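

On the core of compound 3, bromo in place of butoxy gives a 1.4-fold higher number from compound 3 to compound 4 (0.15 log units; within the scatter) in this assay. Set beside the same change on the core of compound 1, the step shows no difference that can be told apart between the two cores: the same change on two cores in this assay, a 1.1-fold higher number (0.04 log units; within the scatter) from compound 1 to compound 2 and a 1.4-fold higher number (0.15 log units; within the scatter) from compound 3 to compound 4, 1.3-fold (0.11 log units) apart, within the scatter of two such steps What this shows is limited to these two pairs, where the exchange leaves the number within the scatter on both cores; it does not show that the two steps are truly equal in size, nor that the change would behave the same way on any further core in the series.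

The compounds shown leave open whether another group on this aromatic carbon, such as an amine, a carboxylic acid or a chain longer than butoxy, would move the number in this assay beyond the scatter. They also leave open how bromo in place of butoxy reads on any core other than these two.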